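Dropping the Carbamoyl: From Compound 2 to Compound 3

The source may report more compounds than this note shows. Statements on the series, on what has been measured and on what is new or still open speak of the compounds shown alone.

Measured so far:
compound 1, `C[C@@H]1CCCN1c1c(C#N)c2c(N)nccc2n1C`, 0.8 nM
compound 2, `C[C@@H]1CCCN1c1c(C(N)=O)c2c(N)ncnc2n1C`, 77 nM

Both compounds were tested in an assay on isolated protein for binding affinity to Leucine-rich repeat serine/threonine-protein kinase 2 (Homo sapiens), read by TR-FRET and LanthaScreen, with a stated time of 2 h; on this read-out lower numbers stand for stronger inhibition and higher numbers for weaker inhibition. Compound 1 gives 0.8 nM in this assay, while compound 2 gives 77 nM. Compound 2 thus stands at the higher of the two numbers, and its gap to compound 1 lies well beyond the scatter of repeated measurements. Among the compounds with values here, the two compounds differ in more than one place, so their values show only that compound 1 binds more strongly than compound 2, without pointing to a single cause.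

The step under consideration leads from compound 2 to compound 3, `C[C@@H]1CCCN1c1cc2c(N)ncnc2n1C`. The change is hydrogen in place of carbamoyl on an aromatic carbon. Nothing measured here isolates the contribution of the carbamoyl group, so the expected direction rests on the general observation that removing a substituent from a shared core tends to weaken binding rather than strengthen it. For compound 3 the estimated step is a 3.2-fold higher number from compound 2 to compound 3 (0.51 log units; beyond the scatter), expected to lie somewhat beyond the scatter. Compound 3 is therefore expected to give about 250 nM in this assay, within a range from 60 nM to 1200 nM.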

Compound 3, inhibition constant: 164 nM
The estimate for compound 3 lay 1.5-fold (0.18 log units) above the measured number, and the stated range covers the measured number.
By their numbers in this assay, from the lowest: compound 1; then compound 2; then compound 3.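

In this assay, within the data shown here, the step from carbamoyl to hydrogen on this aromatic carbon of the five-membered ring is a 2.1-fold higher number from compound 2 to compound 3 (0.33 log units; beyond the scatter), and it is the first change in this set that can be read at a single place. The step is modest yet beyond the scatter, so this position is not indifferent to what it carries, while binding persists on the shared core with only hydrogen there, and the carbamoyl group is not required for a measurable number in this assay. Nothing shown here explains why the step has this direction or this size.

The compounds shown leave open whether methyl, a fluorine atom, an aminomethyl group or a carboxylic acid on this aromatic carbon would give a lower or a higher number than carbamoyl or hydrogen. They also leave open what the nitrile of compound 1 would give on the core of compound 2, as compound 1 and compound 2 differ in more than one place.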